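The source may hold more compounds than are shown below. What is called first, only, known or untested is meant among the compounds shown, and "the series" means these compounds.

Compound 1 `NC(=O)c1cnn(-c2ccc(S(N)(=O)=O)cc2)c1N`: in a functional assay on MCF7 cells (Homo sapiens) for cytotoxicity, read by MTT assay, with a stated time of 72 h (on this read-out lower numbers stand for stronger inhibition and higher numbers for weaker inhibition), compound 1 reaches only the limit > 100000 nM.
Compound 2 `NS(=O)(=O)c1ccc(-n2ncc3c(=O)[nH]c(-c4ccccc4)nc32)cc1`: in this assay compound 2 likewise gives only the limit > 100000 nM.
Compound 3 `NS(=O)(=O)c1ccc(-n2ncc3c(=O)[nH]c(-c4ccc(Cl)cc4)nc32)cc1`: in this assay compound 3 gives 2500 nM.

For the measured compounds named here, compound 3 thus stands as the only compound with an actual number; the other two values are limits (the limit of > 100000 nM in this assay, at which 2 of the 3 values shown sit). Going by the values given here, the single measured step, an at least 40-fold lower number from compound 2 to compound 3 (1.60 log units; beyond the scatter), shows that one small change on an aromatic carbon can shift the result greatly. Compound 4 `COc1ccc(-c2nc3c(cnn3-c3ccc(S(N)(=O)=O)cc3)c(=O)[nH]2)cc1OC` differs from compound 3 by 3,4-dimethoxyphenyl in place of 4-chlorophenyl on an aromatic carbon. Among the compounds with values here, no measured step covers this exchange, so its direction is uncertain, and the gap between compound 2 and compound 3 warns that it could be large in either direction. Compound 4 is expected to give about 10000 nM, within 2000 nM to 100000 nM. The estimated step of a 4.0-fold higher number from compound 3 to compound 4 (0.60 log units; beyond the scatter) is therefore a modest weakening.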

Compound 4, half-maximal inhibitory concentration: > 100000 nM
Compound 4 gave a limit, no number; the forecaster's own chance of this, stated with the estimate: 35%; at least 10-fold (1.00 log units) between middle value and limit.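

Exchanging the group on this aromatic carbon brings an at least 40-fold higher number from compound 3 to compound 4 (1.60 log units; beyond the scatter) in this assay, so the gain seen with chloro on the phenyl ring does not carry over to 3,4-dimethoxyphenyl. Among the groups shown at this place, only 4-chlorophenyl gives a number, and the others end at a limit: the limit of > 100000 nM in this assay, at which 3 of the 4 values shown sit. The step between compound 2 and compound 4 cannot be read: both values are limits.

Still open, from the compounds shown here alone, is whether 4-methoxyphenyl, with a single methoxy group, would give a number. The same holds for an amine or a carboxylic acid in place of the chloro group.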